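This account rests on a few compounds, and the source may have more. Where it says the series, first, only, none or still open, it means among the compounds named here.

Compound 1 `COc1cc(/C=C2\CC/C(=C\c3ccc([N+](=O)[O-])cc3)C2=O)cc(OC)c1OC`: in a functional assay on HSC-3 cells (Homo sapiens) for cytotoxicity (on this read-out lower numbers stand for higher toxicity in this test and higher numbers for lower toxicity in this test), a limit, > 400000 nM.
Compound 2 `COc1cc(/C=C2\Cc3ccccc3/C(=C\c3ccc([N+](=O)[O-])cc3)C2=O)ccc1O`: in this assay the number 3800 nM.
Compound 3 `COc1cc(/C=C2/C(=O)/C(=C/c3ccc([N+](=O)[O-])cc3)c3ccccc32)cc(OC)c1OC`: in this assay a limit, > 400000 nM.

Within the data shown here, compound 2 thus holds the only number in the set; the other two sit at the limit of > 400000 nM in this assay, at which 2 of the 3 values shown sit. Compound 4 `O=C1/C(=C/c2ccc(O)cc2)Cc2ccccc2/C1=C\c1ccc([N+](=O)[O-])cc1` follows from compound 2 by hydrogen in place of methoxy on an aromatic carbon. Among the measured compounds shown here, no measured pair covers this change, so its size is not known from the data. The expectation for compound 4 is a step of a 1.3-fold higher number from compound 2 to compound 4 (0.12 log units; within the scatter) of no more than modest size, leaning toward a small loss rather than a gain. Compound 4 is therefore estimated at 5000 nM, within 1500 nM to 20000 nM.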

Compound 4, half-maximal cytotoxic concentration: 14000 nM
Estimate against measurement, compound 4: 2.8-fold (0.45 log units) below; measured number inside the range.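

In this assay, replacing the methoxy group ortho to a hydroxy group with hydrogen gives a 3.7-fold higher number from compound 2 to compound 4 (0.57 log units; beyond the scatter). Among these compounds, this is the first readable step, and it shows that this position registers in this read-out: the methoxy group of the 4-hydroxy-3-methoxyphenyl ring is not needed for a measurable value, but losing it lowers toxicity in this test.

Steps to compound 1 and compound 3 cannot be read: the limit of > 400000 nM in this assay, at which 2 of the 4 values shown sit. Whether an ethoxy group, a chlorine atom or an amine at this position would match methoxy or hydrogen remains open.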